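Working notes: a third substituent on the ring amine nitrogen

The source may hold more compounds than are shown below. What is called first, only, known or untested is meant among the compounds shown, and "the series" means these compounds.

Measured so far:
compound 1, `Nc1scc(CN2CCN(c3ccc(Cl)c(C(F)(F)F)c3)CC2)c1C(=O)c1ccc(Cl)cc1`: 3%
compound 2, `Nc1scc(CN2CCN(c3ccncc3)CC2)c1C(=O)c1ccc(Cl)cc1`: 2%

In an assay on CHO cells for displacement of a labelled ligand from adenosine receptor A3 (Homo sapiens), read by scintillation counting, with a stated time of 120 min, tested at 10 uM (a lower number here means less inhibition, a higher number more inhibition at the concentration tested (going by the name of the read-out)), compound 1 gives 3% and compound 2 gives 2%. Compound 2 holds the lowest of the two numbers, with compound 1 the nearest, and the gap between them lies within the scatter. Among the measured compounds shown here, the only measured step, a number 1 percentage points lower from compound 1 to compound 2 (within the scatter), exchanges the group on the amine nitrogen in a ring without moving the read-out beyond the scatter.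

Compound 3, `Nc1scc(CN2CCN(c3cc(F)cc(F)c3)CC2)c1C(=O)c1ccc(Cl)cc1`, varies the same position: 3,5-difluorophenyl in place of pyridin-4-yl on an amine nitrogen in a ring. For the measured compounds named here, the one step that bears on this change is the one from compound 1 to compound 2, and it was small. Two different groups at this site have given the same low inhibition in this assay, so no step beyond the scatter is expected here either. Compound 3 is expected to give 3%, in a range from -5% to 12%. For compound 3 this means an expected step of a number 1 percentage points higher from compound 2 to compound 3 (within the scatter).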

Compound 3, a percentage reported as inhibition, at one concentration (the size of the read-out at that concentration, not a potency): 2%
Estimate against measurement, compound 3: 1 percentage points above; the measured number falls inside the stated range.
By their numbers in this assay, from the lowest: compounds 2, 3 and 1 (each within the scatter of the next).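

Putting 3,5-difluorophenyl in place of pyridin-4-yl gives no change at the digits printed from compound 2 to compound 3 (within the scatter) in this assay and, in place of 4-chloro-3-(trifluoromethyl)phenyl, gives a number 1 percentage points lower from compound 1 to compound 3 (within the scatter) in the same assay. Three six-membered aromatic rings on the amine nitrogen in a ring now read alike, and this change, which takes out the ring nitrogen of pyridin-4-yl and brings in two fluorine atoms, moves the number no further than the scatter. Nothing measured here explains why the numbers at this position stay together.

Going by these compounds, all three groups at this position are aromatic rings directly on the nitrogen, so a benzyl group, a cyclohexyl ring or a longer alkyl chain there remains open. Also open, on these data alone, is the effect of a change elsewhere on the shared core, such as an amide in place of the free amine.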